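The source may report more compounds than this note shows. Statements on the series, on what has been measured and on what is new or still open speak of the compounds shown alone.

Measured compounds in an ADME assay on HCT-15 cells (Homo sapiens) for cytotoxicity, read by sulforhodamine B assay, with a stated time of 48 h; on this read-out lower numbers stand for stronger inhibition and higher numbers for weaker inhibition:
Compound 1, `CO[C@H]1CCN2O[C@H]3C=CC[C@@]4(OC(=O)C=C34)[C@@H]2C1`, gives > 10000 nM, which is a limit of the assay rather than a number.
Compound 2, `O=C1C=C2C=C[C@H](O)C[C@]2(c2ccccn2)O1`, gives > 10000 nM, which is likewise a limit.

In this assay, for the measured compounds named here, compound 2 stands at the limit, and the one further value shown sits there as well, so that the limit of > 10000 nM in this assay, at which 2 of the 2 values shown sit, sums up all that is known: no number has been reached for either compound, and no order between them can be drawn. Compound 2 carries a hydroxy on a saturated ring carbon of a six-membered non-aromatic ring of carbon only, part of a fused or bridged system of two rings. Compound 3, `O=C1C=C2C=CCC[C@]2(c2ccccn2)O1`, differs from it in one place: hydrogen in place of hydroxy on a saturated ring carbon. Going by the values given here, no step between two measured compounds is available here, so no size of effect for such a change can be taken from measured pairs. The expectation is that the step that the limit leaves unreadable from compound 2 to compound 3 stays within the scatter. Compound 3 is accordingly estimated at 20000 nM, in the range 8000 nM to 60000 nM, and is expected most likely to be reported again only as a limit.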

Compound 3, half-maximal inhibitory concentration: > 10000 nM
Compound 3: a limit, no number (the forecaster's own chance of this, stated with the estimate: 85%); the middle value lies beyond the limit too.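

No step can be read between compound 2 and compound 3, as both stand only at a limit and not at a number: the limit of > 10000 nM in this assay, at which 3 of the 3 values shown sit.

The compounds shown leave open whether hydrogen in place of hydroxy on a saturated ring carbon changes anything in this assay, and how compound 1, compound 2 and compound 3 would rank there.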